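This account rests on a few compounds, and the source may have more. Where it says the series, first, only, none or still open, it means among the compounds named here.

Compound 1 `COc1cccc(OC)c1C(=O)Nc1c[nH]nc1C(=O)NCc1ccccc1` belongs to a small set measured in an ADME assay on MRC5 cells (Homo sapiens) for inhibition, with a stated time of 72 h (a higher number here means that more compound is needed for the effect, a lower number that less compound is needed), where compound 1 gives 50000 nM. Among the measured compounds shown here, this is the highest of the two numbers available, but the only neighbour, compound 2 `COc1cccc(OC)c1C(=O)Nc1c[nH]nc1C(=O)NC1CCN(Cc2ccccc2)C1`, gives 38000 nM in this assay, and the gap between the two lies within the scatter of repeated measurements, so neither can be called different from the other. For the measured compounds named here, no pair of compounds that differ in a single place has been measured, so there is no step of known size to lean on.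

Compound 3 `COc1cccc(OC)c1C(=O)Nc1c[nH]nc1C(=O)NC1CCCCC1` departs from compound 1 by one change: cyclohexyl in place of benzyl on an amide-type nitrogen. Both numbers seen so far sit at high concentrations, and nothing in them points in either direction for this change. The expected step of a 1.1-fold lower number from compound 1 to compound 3 (0.05 log units; within the scatter) is therefore none beyond the scatter. In this assay compound 3 is estimated at 45000 nM, within a range from 18000 nM to 110000 nM.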

Compound 3, half-maximal effective concentration: 35000 nM
Beside the measured number, compound 3's estimate is 1.3-fold (0.11 log units) above it; the measured number falls inside the stated range.
By their numbers in this assay, from the lowest: compounds 3, 2 and 1 (each within the scatter of the next).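

Among the compounds shown here, this is the first pair in the set that differs in one place only, so the change on the amide-type nitrogen can now be sized directly: in this assay, cyclohexyl in place of benzyl gives a 1.4-fold lower number from compound 1 to compound 3 (0.15 log units; within the scatter) and so stays within the scatter. At this position, then, a six-membered aromatic ring of carbon and a six-membered non-aromatic ring of carbon cannot be told apart by this read-out. Nothing available here offers an explanation for this result.

Open, on these data alone, is whether a different kind of group on this nitrogen, such as a carboxylic acid or an amine, would produce a step beyond the scatter. Also open, as far as these compounds go, is whether a small methyl group or a longer chain in the same place would do so.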